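Terminal Aryl Swap: Phenyl to 6-Methylpyridin-3-yl

The source may hold more compounds than are shown below. What is called first, only, known or untested is meant among the compounds shown, and "the series" means these compounds.

Compound 1 `CN1C(=O)C2=C(C1=O)N(CC(=O)Nc1ccc(-c3cccnc3)nn1)CCC2`: 29 nM
Compound 2 `CN1C(=O)C2=C(C1=O)N(CC(=O)Nc1ccc(-c3ccccc3)nn1)CCC2`: 1 nM
Compound 3 `CN1C(=O)C2=C(C1=O)N(CC(=O)Nc1ccc(-c3ccncc3)cc1)CCC2`: 72 nM

In an assay on cells for inhibition of Protein-serine O-palmitoleoyltransferase porcupine (Homo sapiens), read by reporter gene assay (on this read-out higher numbers stand for weaker inhibition and lower numbers for stronger inhibition), compound 2 gives 1 nM, the lowest of the three numbers. Compound 1 gives 29 nM and compound 3 gives 72 nM, both beyond the scatter above compound 2.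

Compound 4 `Cc1ccc(-c2ccc(NC(=O)CN3CCCC4=C3C(=O)N(C)C4=O)nn2)cn1` differs from compound 2 by 6-methylpyridin-3-yl in place of phenyl on an aromatic carbon. Within the data shown here, the one measured step that bears on this is a 29-fold lower number from compound 1 to compound 2 (1.46 log units; beyond the scatter), where phenyl replaced pyridin-3-yl. Compound 4 reintroduces a pyridin-3-yl ring, now carrying a methyl group, so the step from compound 2 to compound 4 is expected to run the other way and raise the number beyond the scatter, by a 20-fold higher number from compound 2 to compound 4 (1.30 log units; beyond the scatter). Compound 4 is therefore estimated at 20 nM, with a range from 5 nM to 80 nM.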

Compound 4, half-maximal inhibitory concentration in the Protein-serine O-palmitoleoyltransferase porcupine assay: 29 nM
The estimate for compound 4 lay 1.5-fold (0.16 log units) below the measured number; measured number inside the range.
By their numbers in the Protein-serine O-palmitoleoyltransferase porcupine assay, from the lowest: compound 2; then compounds 1 and 4 (each within the scatter of the next); then compound 3.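

At this aromatic carbon, the methyl adds nothing to potency and the loss stays with the ring nitrogen: in the Protein-serine O-palmitoleoyltransferase porcupine assay there is a 29-fold higher number from compound 2 to compound 4 (1.46 log units; beyond the scatter), but no change at the digits printed from compound 1 to compound 4 (within the scatter). In a physicochemical assay for solubility, measured as thermodynamic solubility, at pH 7.4 (on this read-out higher numbers stand for higher solubility and lower numbers for lower solubility), compound 2 gives 3.34 ug/mL and compound 4 gives 35.5 ug/mL. The same swap also gives a higher number in the physicochemical assay: the measured solubility of compound 2, 3.34 ug/mL, and of compound 4, 35.5 ug/mL, an 11-fold higher number (1.03 log units; beyond the scatter)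

The compounds shown leave open whether the ring nitrogen or the methyl accounts for that solubility change. They also leave open whether a methoxy group or an amine on this terminal ring would bring the number in the Protein-serine O-palmitoleoyltransferase porcupine assay back towards that of compound 2 while keeping the solubility.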